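A few compounds are considered here, and "the series" means these few. Any claim that something is new, unique, unknown or untested is made for them only; others in the source may bear on it.

Of the compounds shown here, three sharing one core have been measured in a functional assay (Left cardiac atrium, Cavia porcellus), with a stated time of 30 min; a lower number here means that less compound is needed, a higher number that more compound is needed for the effect. Compound 1 `COc1cccc(C2(OCC3CCCCC3)SC=C(C)n3c2noc3=O)c1` gives 650 nM, compound 2 `COc1ccccc1C1(O)SC=C(C)n2c1noc2=O` gives 930 nM, and compound 3 `CCOC1(c2ccccc2OC)SC=C(C)n2c1noc2=O` gives 140 nM, the lowest of the three numbers. Compound 4 `COc1ccccc1C1(OCC2CCCCC2)SC=C(C)n2c1noc2=O` departs from compound 3 at the ether: cyclohexyl in place of methyl on a saturated chain carbon bound to an oxygen on a saturated carbon. This places cyclohexyl in place of methyl on a saturated chain carbon bound to an oxygen on a saturated carbon, turning ethoxy into cyclohexylmethoxy. Among the measured compounds shown here, only one measured step touches this oxygen, a 6.6-fold lower number from compound 2 to compound 3 (0.82 log units; beyond the scatter), a modest change beyond the scatter, and it shows that the substituent there matters in this assay. It does not show how a larger group behaves. Compound 1 also carries cyclohexylmethoxy but differs elsewhere as well, and its value of 650 nM gives only a loose hint that the number may rise. A small rise is therefore expected, possibly no larger than the scatter, and the expected change is a 1.8-fold higher number from compound 3 to compound 4 (0.25 log units; within the scatter). For compound 4 the estimated value is 250 nM, with an expected range of 80 nM to 800 nM.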

Compound 4, half-maximal effective concentration: 480 nM
For compound 4 the middle estimate is 1.9-fold (0.28 log units) below the measured one; the range from low to high includes it.
By their numbers in this assay, from the lowest: compound 3; then compounds 4, 1 and 2 (each within the scatter of the next).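

In this assay, the size of the group on this oxygen now proves to matter, with a 3.4-fold higher number from compound 3 to compound 4 (0.54 log units; beyond the scatter) when cyclohexyl takes the place of methyl on the saturated chain carbon. The benefit seen with ethyl does not carry over to cyclohexylmethyl, since replacing hydrogen on this oxygen with that group gives a 1.9-fold lower number from compound 2 to compound 4 (0.29 log units; within the scatter) and so leaves no change beyond the scatter. With cyclohexylmethoxy in place, the position of the methoxy group also makes no difference beyond the scatter, as 2-methoxyphenyl in place of 3-methoxyphenyl gives a 1.4-fold lower number from compound 1 to compound 4 (0.13 log units; within the scatter) here.

No evidence is available to explain the rise that comes with the larger group. On these data alone, how a propyl chain or a benzyl group on this oxygen would read remains open, as does whether 3-methoxyphenyl would behave the same way alongside ethoxy.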